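This account rests on a few compounds, and the source may have more. Where it says the series, first, only, none or still open, it means among the compounds named here.

Compounds measured in a functional assay on RAW264.7 cells (Mus musculus) for inhibition, read by Griess assay, with stated times of 1 h and 24 h; a lower number here means a stronger inhibitor, a higher number a weaker inhibitor: compound 1 `CC(C)CCOc1ccccc1C1CC(=O)c2ccccc2O1` gives 39200 nM; compound 2 `CCCOc1ccccc1C1CC(=O)c2ccccc2O1` gives 46000 nM; compound 3 `C=CCOc1ccccc1C1CC(=O)c2ccccc2O1` gives 37800 nM.

Compound 2 has the highest of the three numbers, yet the step of a 1.2-fold higher number from compound 1 to compound 2 (0.07 log units; within the scatter) and the step of a 1.2-fold lower number from compound 2 to compound 3 (0.09 log units; within the scatter) are both small, so the three stand together within the scatter. Compound 4 `CCCCCOc1ccccc1C1CC(=O)c2ccccc2O1` differs from compound 2 by ethyl in place of hydrogen on a saturated chain carbon, three bonds along the chain from an oxygen on an aromatic ring. Among the compounds with values here, the step most akin to this chain change is the one from compound 1 to compound 2, which gave a 1.2-fold higher number from compound 1 to compound 2 (0.07 log units; within the scatter), and the step from compound 1 to compound 3 gave a 1.0-fold lower number from compound 1 to compound 3 (0.02 log units; within the scatter); neither left the scatter. Compound 4 is therefore expected to show no step beyond the scatter, about a 1.1-fold lower number from compound 2 to compound 4 (0.04 log units; within the scatter). The estimate for compound 4 in this assay is 42000 nM, within 24000 nM to 75000 nM.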

Compound 4, half-maximal inhibitory concentration: 39200 nM
Estimate against measurement, compound 4: 1.1-fold (0.03 log units) above, within the range that was stated.
By their numbers in this assay, from the lowest: compounds 3, 1, 4 and 2 (each within the scatter of the next).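

In this assay, ethyl in place of hydrogen, three bonds along the chain from an oxygen on an aromatic ring, stays within the scatter (a 1.2-fold lower number from compound 2 to compound 4 (0.07 log units; within the scatter)), so the longer chain of compound 4 shifts nothing that can be read. Compound 4 also stays within the scatter of the vinyl and isopropyl compounds (a 1.0-fold higher number from compound 3 to compound 4 (0.02 log units; within the scatter); no change at the digits printed from compound 1 to compound 4 (within the scatter)), so propyl in place of isopropyl leaves the number unmoved as well. Nothing available gives a reason for this.

From the compounds shown here alone, whether an amine, a carboxylic acid or a much longer chain on this oxygen would give a step beyond the scatter stays open.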